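The source may hold more compounds than are shown below. What is called first, only, known or untested is meant among the compounds shown, and "the series" means these compounds.

Compound 1 `N#CC1=C(N)Oc2c(N)cc3nc4ccccc4nc3c2C12C(=O)N(Cc1cnnn1-c1ccccc1Cl)c1ccccc12`. In an ADME assay on L02 cells (Homo sapiens) for antiproliferative activity, read by MTT assay, with a stated time of 48 h (on this read-out higher numbers stand for weaker inhibition and lower numbers for stronger inhibition), compound 1 gives > 50000 nM, a limit of the assay.
Compound 2 `N#CC1=C(N)Oc2c(N)cc3nc4ccccc4nc3c2C12C(=O)N(Cc1cnnn1-c1ccccc1Br)c1ccccc12`. In this assay compound 2 gives 29200 nM.
Compound 3 `CCOc1ccccc1-n1nncc1CN1C(=O)C2(C(C#N)=C(N)Oc3c(N)cc4nc5ccccc5nc4c32)c2ccccc21`. In this assay compound 3 gives > 50000 nM, again a limit of the assay.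

Compound 3 thus stands at the edge of what this assay reports, and it shares the limit of > 50000 nM in this assay, at which 2 of the 3 values shown sit, with compound 1; only compound 2 has a number. The measured steps are a step that the two limits leave unreadable from compound 1 to compound 3, an at least 1.7-fold higher number from compound 2 to compound 3 (0.23 log units; that floor lies within the scatter) and an at least 1.7-fold lower number from compound 1 to compound 2 (0.23 log units; that floor lies within the scatter). All three exchange the substituent on the aromatic ring that sits on the aromatic nitrogen of the five-membered ring with three nitrogens, and none of them is resolved beyond the scatter. Compound 4 `Cc1ccc(C)c(-n2nncc2CN2C(=O)C3(C(C#N)=C(N)Oc4c(N)cc5nc6ccccc6nc5c43)c3ccccc32)c1` differs from compound 3 at that same place: 2,5-dimethylphenyl in place of 2-ethoxyphenyl on an aromatic nitrogen. Among the compounds with values here, with these steps as the only guide, the expected change in this assay is none beyond the scatter, and a limit is the most probable outcome again. Compound 4 is therefore estimated at 60000 nM, with a range from 25000 nM to 150000 nM, meaning an expected step that the limit leaves unreadable from compound 3 to compound 4.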

Compound 4, half-maximal inhibitory concentration: > 50000 nM
Compound 4: no number, only a limit; the forecaster's own chance of this, stated with the estimate: 65%; the middle value lies beyond the limit too.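

Compound 4 also gives only a limit in this assay, so 2,5-dimethylphenyl, which has no oxygen and no hydrogen-bond acceptor, ends at the same limit as the 2-ethoxyphenyl of compound 3: the limit of > 50000 nM in this assay, at which 3 of the 4 values shown sit. The steps to compound 4 from compound 1 and from compound 3 cannot be read, as both ends of each are limits. Within the data shown here, the one readable step is an at least 1.7-fold higher number from compound 2 to compound 4 (0.23 log units; that floor lies within the scatter), so even 2-bromophenyl, the only group here with a number, is not clearly set apart from 2,5-dimethylphenyl.

The compounds shown leave open whether any group at this position can give a number clearly clear of the limit, and how far the compounds at the limit differ from one another. On these data alone, a phenyl ring carrying an amine or a carboxylic acid does not appear among them, so its effect here remains unknown.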